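Iodo for Bromo at the Floor of the Assay

The compounds below may be only part of what the source reports. "The series", "measured", "known", "first", "only" and "open" are said of these compounds alone.

Measured compounds:
compound 1, `CCc1cc(N)ccc1-c1nc2ccccc2s1`, < 0.1 nM
compound 2, `Nc1ccc(-c2nc3ccccc3s2)c(Br)c1`, < 0.1 nM

In a functional assay on MDA-MB-468 cells (Homo sapiens) for inhibition (a higher number here means a weaker inhibitor, a lower number a stronger inhibitor), compound 1 gives < 0.1 nM, which is a limit of the assay rather than a number. In this assay compound 2 gives < 0.1 nM, likewise a limit. The step that the two limits leave unreadable from compound 1 to compound 2 therefore cannot be sized. Compound 2 thus stands at the limit of < 0.1 nM in this assay, at which 2 of the 2 values shown sit, and no order between compound 1 and compound 2 can be read.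

Compound 3, `Nc1ccc(-c2nc3ccccc3s2)c(I)c1`, differs from compound 2 in one place: iodo in place of bromo on an aromatic carbon. Among the measured compounds shown here, the only measured step, from compound 1 to compound 2, is unreadable, so it gives no usable size for this change. The author expects compound 3 to remain at or near the floor of this assay, the expected step being a step that the limit leaves unreadable from compound 2 to compound 3. The estimate for compound 3 is 0.07 nM, in the range 0.02 nM to 0.3 nM, with a limit again likely.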

Compound 3, half-maximal inhibitory concentration: < 0.1 nM
Compound 3: no number, only a limit (the forecaster's own chance of this, stated with the estimate: 70%); the middle value lies beyond the limit too.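

Compound 3 also gives only a limit, so its steps from compound 1 and compound 2 cannot be read, and no order among the three follows: the limit of < 0.1 nM in this assay, at which 3 of the 3 values shown sit.

The compounds shown leave open whether ethyl, bromo or iodo on this aromatic carbon makes any difference in this assay.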